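The source may report more compounds than this note shows. Statements on the series, on what has been measured and on what is new or still open speak of the compounds shown alone.

Values in an ADME assay on TERT-RPE1 cells (Homo sapiens) for cytotoxicity, read by MTT assay, with a stated time of 72 h; a lower number here means a stronger inhibitor, a higher number a weaker inhibitor:
- Compound 1 `COc1ccc(/C=C2\S/C(=N\c3ccc(C)c(Cl)c3)N(C)C2=O)cc1`: 23000 nM
- Compound 2 `COc1ccc(/C=C2\S/C(=N\c3ccc(F)cc3)N(C)C2=O)cc1`: > 100000 nM
- Compound 3 `COc1ccc(/C=C2\S/C(=N\c3c(C)cccc3C)N(C)C2=O)cc1`: not yet measured

In this assay compound 2 gives > 100000 nM, which is a limit and not a number. The next change is 2,6-dimethylphenyl in place of 4-fluorophenyl on a double-bonded nitrogen, with 2,6-dimethylphenyl in place of 4-fluorophenyl on a double-bonded nitrogen. Among the compounds with values here, the one measured step at this place, an at least 4.3-fold higher number from compound 1 to compound 2 (0.63 log units; beyond the scatter), lies beyond the scatter. Within the data shown here, with compound 1 at 23000 nM, a move back towards a lower number is expected for compound 3, though only this single step supports it. The expected change is an at least 1.6-fold lower number from compound 2 to compound 3 (0.22 log units; that floor lies within the scatter). For compound 3 the estimate is 60000 nM, with an expected range of 20000 nM to 150000 nM.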

Compound 3, half-maximal inhibitory concentration: > 100000 nM
Compound 3: a limit, no number (the forecaster's own chance of this, stated with the estimate: 45%); middle value at least 1.6-fold (0.22 log units) from the limit.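

In this assay, replacing 3-chloro-4-methylphenyl with 2,6-dimethylphenyl on a double-bonded nitrogen gives an at least 4.3-fold higher number from compound 1 to compound 3 (0.63 log units; beyond the scatter), so a second group now lies on the higher side of the first. Compound 2 and compound 3 both read as limits, so the step between them cannot be read. Only compound 1 gives a number at this place, and comparison among the others stops at the limit: the limit of > 100000 nM in this assay, at which 2 of the 3 values shown sit.

As far as these compounds go, how far compound 2 and compound 3 lie past that limit stays open. So does whether a phenyl carrying an amine or a carboxylic acid at this place would return a number.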